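The source may hold more compounds than are shown below. What is called first, only, known or untested is meant among the compounds shown, and "the series" means these compounds.

Measured in an ADME assay on HeLa cells (Homo sapiens) for cytotoxicity, read by resazurin assay, with a stated time of 2 days; a lower number here means a stronger inhibitor, a higher number a weaker inhibitor:
- compound 1 `Cc1ccccc1/C=C/c1ncc([N+](=O)[O-])n1C`: 93300 nM
- compound 2 `Cn1c([N+](=O)[O-])cnc1/C=C/c1cccc(Br)c1`: 87100 nM
- compound 3 `Cn1c([N+](=O)[O-])cnc1/C=C/c1ccc(Br)cc1`: 72400 nM

The three compounds share one core and carry different substituents on its aromatic ring of carbon only. In this assay, compound 2 at 87100 nM lies within the usual scatter of both other compounds. Its value cannot be separated from that of compound 1 at 93300 nM or from that of compound 3 at 72400 nM. These three numbers therefore form a single tight group, and no order among them can be read with confidence.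

The next compound to be tested is compound 4 `Cn1c([N+](=O)[O-])cnc1/C=C/c1cccc(I)c1`. It differs from compound 2 by one change: iodo in place of bromo on an aromatic carbon. Among the compounds with values here, no pair of measured compounds shows a single change of this kind, so the data offer no direct precedent for it. The expectation rests only on the narrow group of values seen so far, and no step beyond the scatter is anticipated. The expected change is a 1.1-fold lower number from compound 2 to compound 4 (0.05 log units; within the scatter), an estimate that stays within the scatter. For compound 4 the estimated value is 78000 nM, with an expected range from 45000 nM to 130000 nM.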

Compound 4, half-maximal inhibitory concentration: 31600 nM
Beside the measured number, compound 4's estimate is 2.5-fold (0.39 log units) above it; the measured number lies below the stated range.
By their numbers in this assay, from the lowest: compound 4; then compounds 3, 2 and 1 (each within the scatter of the next).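

In this assay, iodo in place of bromo on an aromatic carbon, meta to a large group, gives a 2.8-fold lower number from compound 2 to compound 4 (0.44 log units; beyond the scatter) in a single change, a modest step but one beyond the scatter. The earlier compounds shown here offered no single change to read and no separation among their values, so they could not show that the number responds to the halogen at this place; this pair shows that exchanging one halogen for the other is enough to move it. No measurement shown here accounts for the step, and its cause remains unknown.

One pair cannot show whether the number follows a trend through the halogens, and a chloro or fluoro group at the same carbon would be needed to test that, while an amine or a carboxylic acid there would show whether the response extends beyond halogens. On these data alone, it also remains open whether iodo would give a similar step at the ring carbon that carries bromo in compound 3, or whether this effect belongs to the one place alone.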